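The compounds below may be only part of what the source reports. "The series", "measured", "known", "first", "only" and "open" are said of these compounds alone.

In an ADME assay on the whole organism (plasma, strain Sprague-Dawley) for pharmacokinetics, with Rattus norvegicus as the target, at a dose of 5 mg/kg by the oral route (on this read-out higher numbers stand for higher exposure at the dose given and lower numbers for lower exposure), compound 1 `CN(C)CC[C@H](CSc1ccccc1)Nc1ccc(S(=O)(=O)NC(=O)c2ccc(N3CCN(Cc4ccccc4-c4ccc(Cl)cc4)CC3)cc2)cc1` offers no number to start from, as its entry reads "not determined" (no result reported). The only figure available in this small set belongs to a relative, compound 2 `CN(C)CC[C@H](CSc1ccccc1)Nc1ccc(S(=O)(=O)NC(=O)c2ccc(N3CCN(CC4=C(c5ccc(Cl)cc5)CCCC4)CC3)cc2)cc1[N+](=O)[O-]`, which gives 531 ng.h/mL. Compound 3 `CN(C)CC[C@H](CSc1ccccc1)Nc1ccc(S(=O)(=O)NC(=O)c2ccc(N3CCN(Cc4ccccc4-c4ccc(Cl)cc4)CC3)cc2)cc1C(=O)C(F)(F)F` is compound 1 with a single change, (trifluoromethyl)carbonyl in place of hydrogen on an aromatic carbon, ortho to a large group and meta to a large group. Among the compounds with values here, no measured pair here shows what a single change does to exposure, so the direction of this step cannot be read from the data. No step beyond the usual scatter is therefore expected in this assay, and the working anchor is compound 2 at 531 ng.h/mL. For compound 3 the estimated value is 350 ng.h/mL, with an expected range of 80 ng.h/mL to 1500 ng.h/mL.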

Compound 3, area under the concentration-time curve: 1080 ng.h/mL
Compound 3: the middle estimate sits 3.1-fold (0.49 log units) below what was measured, and the stated range covers the measured number.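

Compound 3 gives 1080 ng.h/mL in this assay but compound 1 has no number there, so no step can be read between them. On these data alone, whether adding the (trifluoromethyl)carbonyl group raises or lowers exposure stays open. Nothing shown bears on the value of compound 3.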